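This account rests on a few compounds, and the source may have more. Where it says the series, first, only, none or still open, it means among the compounds named here.

Compound 1 `COc1nc2ccc(Br)cc2cc1C(c1ccccc1)n1cc(-c2ccc(Br)cc2)nn1` and compound 2 `CCCCCCCCc1cn(C(c2ccccc2)c2cc3cc(Br)ccc3nc2OC)nn1` share one core. In an ADME assay on PANC-1 cells (Homo sapiens) for cytotoxicity, read by sulforhodamine B assay, with a stated time of 48 h, tested at 10 uM (on this read-out higher numbers stand for more inhibition at the one concentration tested (going by the name of the read-out) and lower numbers for less inhibition), compound 1 gives 10.4%; compound 2 gives 12.1%. The step of a number 1.7 percentage points higher from compound 1 to compound 2 (within the scatter) does not separate the two, and compound 2 stands with compound 1 inside the scatter. Compound 3 `COc1nc2ccc(Br)cc2cc1C(c1ccccc1)n1cc(CCCO)nn1` carries hydroxy in place of pentyl on a saturated chain carbon, three bonds along the chain from an aromatic carbon. Among the compounds with values here, no measured step exchanges a chain for a hydroxy; the only step known, the chain for an aryl group, stayed within the scatter, so no step beyond the scatter is expected in this assay, in either direction, as a number 0.1 percentage points lower from compound 2 to compound 3 (within the scatter). Compound 3 is therefore estimated at 12%, with a range from 3% to 22%.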

Compound 3, a percentage reported as inhibition, at one concentration (the size of the read-out at that concentration, not a potency): 25.5%
The estimate for compound 3 lay 13.5 percentage points below the measured number; the whole stated range lies below it.
By their numbers in this assay, from the lowest: compounds 1 and 2 (each within the scatter of the next); then compound 3.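

In this assay this position on the shared core proves responsive: hydroxy in place of pentyl on a saturated chain carbon, three bonds along the chain from an aromatic carbon, gives a number 13.4 percentage points higher from compound 2 to compound 3 (beyond the scatter) and 3-hydroxypropyl in place of 4-bromophenyl gives a number 15.1 percentage points higher from compound 1 to compound 3 (beyond the scatter), whereas octyl in place of 4-bromophenyl had stayed within the scatter. Both modest steps rest on compound 3 alone. Nothing available here accounts for the higher inhibition.

Still open, from the compounds shown here alone, is whether an amine or a carboxylic acid at the end of the chain would match the hydroxy. Also open, going by these compounds, is whether a longer chain carrying the hydroxy would keep the step.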